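The source may hold more compounds than are shown below. What is called first, only, known or untested is meant among the compounds shown, and "the series" means these compounds.

Among the compounds with values here, in an ADME assay on HepG2 cells (Homo sapiens) for cytotoxicity, read by MTT assay, with a stated time of 24 h (a lower number here means that less compound is tolerated, a higher number that more compound is tolerated), compound 2 `Clc1ccc2c(-n3cc(-c4ccccc4)nn3)ccnc2c1` gives 574000 nM, the only exact number so far. Compound 1 `CN(C)c1ccc(-c2cn(-c3ccnc4cc(Cl)ccc34)nn2)cc1` reaches only a limit, > 2860000 nM. Compound 3 `CC(C)(C)c1ccc(C(=O)OCCCc2cn(-c3ccnc4cc(Cl)ccc34)nn2)cc1` also gives only a limit, > 2230000 nM. Compound 4 `Clc1ccc2c(-n3cc(CN4CCCCC4)nn3)ccnc2c1` keeps the shared core of compound 2 but exchanges its phenyl: (piperidin-1-yl)methyl in place of phenyl on an aromatic carbon. Within the data shown here, the one measured step, an at least 4.9-fold lower number from compound 1 to compound 2 (0.69 log units; beyond the scatter), lies beyond the scatter, but it involves hydrogen in place of dimethylamino on a phenyl that compound 4 no longer carries, so it offers only a weak guide. The expected change in this assay is therefore small and within the scatter, an estimated 1.4-fold higher number from compound 2 to compound 4 (0.14 log units; within the scatter). For compound 4 the estimate is 800000 nM, with an expected range of 200000 nM to 2500000 nM.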

Compound 4, half-maximal cytotoxic concentration: 1110000 nM
Estimate against measurement, compound 4: 1.4-fold (0.14 log units) below; low and high end bracket the measured number.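

In this assay, the phenyl on this aromatic carbon of the five-membered ring gives way to (piperidin-1-yl)methyl, and the result is a 1.9-fold higher number from compound 2 to compound 4 (0.29 log units; within the scatter). The earlier step only altered a group carried on the phenyl, whereas this one replaces the phenyl itself. Even this exchange of an aromatic ring for a non-aromatic ring holding a nitrogen leaves the two values within the usual scatter of each other.

From the compounds shown here alone, whether a morpholine ring or a carboxylic acid at this carbon would also stay within the scatter remains open. Nothing measured here bears on what lies behind this result.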